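The source may report more compounds than this note shows. Statements on the series, on what has been measured and on what is new or still open speak of the compounds shown alone.

Cytotoxicity toward hamster kidney cells is the question here, measured in an ADME assay on BHK-21 cells (Mesocricetus auratus) for cytotoxicity, read by MTT assay, with a stated time of 72 h; a lower number here means that less compound is tolerated, a higher number that more compound is tolerated. Compound 1 `Clc1ccc(NCc2cn(-c3ccccc3)nc2-c2ccc(Br)cc2)cc1` was tested twice, and each time the assay reached its limit and reported > 100000 nM; > 100000 nM (2 entries) for compound 1, so no number is available for it. Within the data shown here, compound 2 `FC(F)(F)c1ccc(NCc2cn(-c3ccccc3)nc2-c2ccccc2)cc1` is the only compound that gives a genuine number: in this assay compound 2 gives 37000 nM. Compound 2 therefore stands as the single measured point of reference, with compound 1 offering only a limit beside it.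

Compound 3 `Clc1ccc(NCc2cn(-c3ccccc3)nc2-c2ccccc2)cc1` has not yet been measured. It differs from compound 2 in one place: chloro in place of trifluoromethyl on an aromatic carbon. Compound 1 also carries chloro on the corresponding ring, and compound 1 is tolerated to the limit of this assay at > 100000 nM; > 100000 nM (2 entries). The step from compound 2 to compound 3 is expected to be modest and toward a higher, better tolerated value, a 1.6-fold higher number from compound 2 to compound 3 (0.21 log units; within the scatter), a step that may not clear the usual scatter. Compound 3 is thus expected to give 60000 nM, within a range of 20000 nM to 150000 nM.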

Compound 3, half-maximal cytotoxic concentration: > 100000 nM
Compound 3: a limit, no number (the forecaster's own chance of this, stated with the estimate: 35%); at least 1.6-fold (0.22 log units) between middle value and limit.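

Among these compounds, this is the first pair of measured compounds that differ in only one place, so it gives the first direct look at the group on an aromatic carbon of this six-membered ring, para to a large group. In this assay, exchanging trifluoromethyl for chloro there gives an at least 2.7-fold higher number from compound 2 to compound 3 (0.43 log units; beyond the scatter), which shows that the cells' tolerance of this series depends on the choice of this single group, with the measurable toxicity belonging to the trifluoromethyl compound in this pair. The step can only be given as a minimum, and its full size remains unknown because compound 3 stops at the top of the readable range: the limit of > 100000 nM in this assay, at which 1 of the 3 values shown sits.

Compound 1 and compound 3 both end at that limit, so nothing can be read between them, and neither compound shows how much further the tolerated concentration might extend. The compounds shown also leave open how the cells would respond to other groups at this position, such as a methoxy group, an amine or a carboxylic acid, and whether any of these would resemble chloro or trifluoromethyl.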